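Diethyl phosphate in place of methyl on the shared core

The source may report more compounds than this note shows. Statements on the series, on what has been measured and on what is new or still open speak of the compounds shown alone.

Measured so far:
compound 1, `COCCc1cn(-c2ccc(NC(=O)Nc3ccccc3C)cc2)nn1`, 1000 nM
compound 2, `CC(C)CC(=O)OCCc1cn(-c2ccc(NC(=O)Nc3ccccc3C(F)(F)F)cc2)nn1`, 400 nM

In an assay on isolated protein for inhibition of ATP-dependent RNA helicase DDX3X (Homo sapiens), read by FRET, with stated times of 30 s and 40 min (on this read-out lower numbers stand for stronger inhibition and higher numbers for weaker inhibition), compound 1 gives the highest of the two numbers recorded; the nearest is compound 2, whose number lies beyond the scatter below it. Compound 3, `CCOP(=O)(OCC)OCCc1cn(-c2ccc(NC(=O)Nc3ccccc3C)cc2)nn1`, has not been measured. It differs from compound 1 as follows: a group of 8 heavy atoms (4 carbon, 3 oxygen, 1 phosphorus; no ring) in place of one carbon atom, on an oxygen on a saturated carbon. Going by the values given here, no step between measured compounds is available for this change, and compound 2 differs from compound 1 in more than one place, so its value alone cannot guide the step. The expected step from compound 1 to compound 3 is a 1.3-fold lower number from compound 1 to compound 3 (0.10 log units; within the scatter), small and within the scatter. Compound 3 is therefore estimated at 800 nM, between 300 nM and 2500 nM.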

Compound 3, half-maximal inhibitory concentration: 890 nM
Estimate against measurement, compound 3: 1.1-fold (0.05 log units) below, and the stated range covers the measured number.
By their numbers in this assay, from the lowest: compound 2; then compounds 3 and 1 (each within the scatter of the next).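

In this assay the change on this oxygen is a 1.1-fold lower number from compound 1 to compound 3 (0.05 log units; within the scatter), so a group of 8 heavy atoms with 3 hydrogen-bond acceptors can replace methyl here with no shift beyond the scatter. Going by these compounds alone, this is the first single-place comparison at this position, and it shows that the number does not follow the large difference in group size across this pair. Nothing available explains this result.

From the compounds shown here alone, whether an amine or a carboxylic acid on this oxygen would also stay within the scatter remains open. So does the separate contribution of each of the two places in which compound 2 differs from compound 1.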